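Lengthening the acid chain from compound 3 to compound 4

The source may report more compounds than this note shows. Statements on the series, on what has been measured and on what is new or still open speak of the compounds shown alone.

Three compounds share one core and differ only in the chain joining their two aromatic parts. Compound 1 `CCCc1c(OCCCOc2c(C(C)=O)ccc(OCC(=O)O)c2CCC)ccc(C(C)=O)c1O` gives 2000 nM in a functional assay on ileum (Cavia porcellus) for inhibition of cysteinyl leukotriene receptor (Homo sapiens); on this read-out higher numbers stand for weaker inhibition and lower numbers for stronger inhibition. Compound 2 `CCCc1c(OCCOCCOc2c(C(C)=O)ccc(OCC(=O)O)c2CCC)ccc(C(C)=O)c1O` gives 200 nM in this assay, and compound 3 `CCCc1c(OCCCOCCCOc2c(C(C)=O)ccc(OCC(=O)O)c2CCC)ccc(C(C)=O)c1O` gives 400 nM in this assay. Among these three numbers compound 3 stands second highest; its nearest neighbour is compound 2, a gap that lies within the scatter, while compound 1 lies furthest off, a gap beyond the scatter toward weaker inhibition.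

Compound 4 `CCCc1c(OCCCOCCCOc2c(C(C)=O)ccc(OCCCC(=O)O)c2CCC)ccc(C(C)=O)c1O` has not yet been measured. It differs from compound 3 by 2-carboxyethyl in place of carboxy on a saturated chain carbon bound to an oxygen on an aromatic ring. Within the data shown here, no measured pair shows this change, so its size cannot be read from the data. A modest move toward weaker inhibition, or none beyond the scatter, is expected for compound 4, a step of a 1.5-fold higher number from compound 3 to compound 4 (0.18 log units; within the scatter). Compound 4 is therefore estimated at 600 nM, with a range from 150 nM to 2500 nM.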

Compound 4, half-maximal inhibitory concentration: 200 nM
Beside the measured number, compound 4's estimate is 3.0-fold (0.48 log units) above it; the measured number falls inside the stated range.
By their numbers in this assay, from the lowest: compounds 2, 4 and 3 (each within the scatter of the next); then compound 1.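

In this assay, replacing carboxy with 2-carboxyethyl on a saturated chain carbon bound to an oxygen on an aromatic ring gives a 2.0-fold lower number from compound 3 to compound 4 (0.30 log units; within the scatter). Among these compounds, this is the first reading of any change at this position, as the earlier compounds differed only in the chain joining their two aromatic parts. On this single pair, the longer acid chain brings no loss of inhibition beyond the scatter, and no evidence at hand bears on this result.

From the compounds shown here alone, whether the same change would give a similar result with the linking chain of compound 1 or compound 2 remains open. Also open, going by these compounds, is whether a still longer chain ending in a carboxylic acid, or a tetrazole in place of the carboxylic acid, would preserve inhibition.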